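Swapping the aryl on the triazole of a farnesyl oxime

The source may hold more compounds than are shown below. What is called first, only, known or untested is meant among the compounds shown, and "the series" means these compounds.

The three measured compounds share one core, seen in compound 1 `CC(C)=CCC/C(C)=C/CC/C(C)=C/CC[C@@H]1[C@@]2(C)CCC(=O)C(C)(C)[C@@H]2CC[C@@]1(C)O`, which in a functional assay on MCF7 cells (Homo sapiens) for cytotoxicity, read by MTT assay, with a stated time of 48 h (a lower number here means a stronger inhibitor, a higher number a weaker inhibitor), gives 16200 nM. Compound 2 `COc1cccc(-n2cc(CO/N=C3\CC[C@]4(C)[C@@H](CC/C=C(\C)CC/C=C(\C)CCC=C(C)C)[C@](C)(O)CC[C@H]4C3(C)C)nn2)c1` carries an oxime ether bearing a triazole with a 3-methoxyphenyl group and in this assay gives 25400 nM. Compound 3 `CC(C)=CCC/C(C)=C/CC/C(C)=C/CC[C@@H]1[C@@]2(C)CC/C(=N\OCc3cn(-c4ccc(F)cc4)nn3)C(C)(C)[C@@H]2CC[C@@]1(C)O` has a 4-fluorophenyl in that position and in this assay gives 26000 nM. Compound 3 thus stands together with compound 2 and compound 1, all three inside the usual scatter of one another, so no order among them can be read.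

Compound 4 `CC(C)=CCC/C(C)=C/CC/C(C)=C/CC[C@@H]1[C@@]2(C)CC/C(=N\OCc3cn(-c4cccc(Br)c4)nn3)C(C)(C)[C@@H]2CC[C@@]1(C)O` differs from compound 3 in one place: 3-bromophenyl in place of 4-fluorophenyl on an aromatic nitrogen. Among the compounds with values here, the only measured step that touches this position is the one in this assay of a 1.0-fold higher number from compound 2 to compound 3 (0.01 log units; within the scatter), which changed nothing beyond the scatter. Nothing measured here says that the aryl group on the triazole moves the number at all, so no step beyond the scatter is expected for compound 4 either, and its estimated step is no change at the digits printed from compound 3 to compound 4 (within the scatter). In this assay compound 4 is therefore expected to give about 26000 nM, within a range from 12000 nM to 55000 nM.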

Compound 4, half-maximal inhibitory concentration: 24800 nM
The estimate for compound 4 lay 1.0-fold (0.02 log units) above the measured number, within the range that was stated.
By their numbers in this assay, from the lowest: compounds 1, 4, 2 and 3 (each within the scatter of the next).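

With a third aryl group in hand, the position can now be read across more than a single exchange: in this assay, the step of a 1.0-fold lower number from compound 3 to compound 4 (0.02 log units; within the scatter) alters both the halogen and its place on the phenyl ring, and it stays within the scatter. The step of a 1.0-fold lower number from compound 2 to compound 4 (0.01 log units; within the scatter) is the cleaner comparison, since 3-methoxyphenyl and 3-bromophenyl differ only in bromo in place of methoxy on an aromatic carbon, and it too stays within the scatter, so 3-methoxyphenyl, 4-fluorophenyl and 3-bromophenyl on the triazole nitrogen cannot be put in any order. No independent measurement bears on this result, so nothing can be said about what lies behind it.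

All three aryl groups shown are phenyl rings with a single neutral substituent, so it remains open whether an amine or a carboxylic acid on that ring would give a number beyond the scatter of these three compounds. Going by these compounds, it is equally open whether a longer alkyl chain or a benzyl group on the triazole nitrogen, in place of the aryl, would do so.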